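Removing the methoxy from compound 2 to give compound 3

The source may hold more compounds than are shown below. What is called first, only, known or untested is meant among the compounds shown, and "the series" means these compounds.

Compound 1 (`Cc1nc(-c2cccnc2)sc1-c1nnc(-c2ccc([N+](=O)[O-])cc2)o1`): in an ADME assay on PANC-1 cells (Homo sapiens) for cytotoxicity, read by MTT assay (on this read-out higher numbers stand for lower toxicity in this test and lower numbers for higher toxicity in this test), compound 1 gives > 100 ug/mL, which is a limit of the assay and not a number.
Compound 2 (`COc1ccccc1-c1nnc(-c2sc(-c3cccnc3)nc2C)o1`): in this assay compound 2 gives > 100 ug/mL, again a limit of the assay rather than a number.

Compound 2 therefore stands at the edge of what this assay can report, and it cannot be placed in order against the other compound shown, because the limit of > 100 ug/mL in this assay, at which 2 of the 2 values shown sit, holds for both of them. For the measured compounds named here, no step between two measured compounds is available to guide what follows. Compound 3 (`Cc1nc(-c2cccnc2)sc1-c1nnc(-c2ccccc2)o1`) is the next member of the series. The change from compound 2 to compound 3 is hydrogen in place of methoxy on an aromatic carbon. Since both values shown sit at the same limit, the step from compound 2 to compound 3 in this assay is expected to be none beyond the scatter, as a step that the limit leaves unreadable from compound 2 to compound 3. Compound 3 is expected to remain at or near that limit, with an estimate in this assay of 150 ug/mL and a range from 70 ug/mL to 400 ug/mL.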

Compound 3, half-maximal cytotoxic concentration: > 100 ug/mL
Compound 3 was reported as a limit; the forecaster's own chance of this, stated with the estimate: 80%; the middle value is on the limit's open side.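

In this assay compound 3 gives > 100 ug/mL as a limit and not a number. For the compounds shown here, no step from compound 1 or compound 2 to compound 3 can be read, because all three compounds sit at the same limit: the limit of > 100 ug/mL in this assay, at which 3 of the 3 values shown sit. The compounds shown leave open whether compound 1, compound 2 and compound 3 differ at all in this assay and what change would bring a value within the range the assay can report.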